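The source may report more compounds than this note shows. Statements on the series, on what has been measured and on what is new or still open speak of the compounds shown alone.

The account follows compound 1 `COc1ccc2[nH]c(C(=O)N3CC(=O)N(Cc4ccccc4)[C@@H](CCc4ccccc4)C3)cc2c1` and the compound derived from it, compound 4 `COc1ccc2[nH]c(C(=O)N3CC(=O)N(Cc4ccccc4)[C@@H](COc4ccc(F)cc4)C3)cc2c1`. In a physicochemical assay for solubility, read by spectrophotometry, in phosphate buffer, with a stated time of 2 h, at pH 7.4 (a lower number here means a less soluble compound, a higher number a more soluble compound), compound 1 gives 4400 nM, the lowest of the three numbers recorded so far. Compound 3 `O=C(c1cc2cc(C3CC3)ccc2[nH]1)N1CC(=O)N(Cc2ccccc2)[C@@H](CN2CCC(F)CC2)C1` gives 12400 nM in this assay, and compound 2 `COc1ccc2[nH]c(C(=O)N3CC(=O)N(Cc4cccc(OC(F)F)c4)[C@@H](CN4CCC(C#N)CC4)C3)cc2c1` gives 27900 nM in this assay; both stand above compound 1 by margins beyond the scatter. For the measured compounds named here, compounds 2 and 3, however, differ from compound 1 in more than one place, so no single step between measured compounds isolates any one change. Compound 4 differs from compound 1 in one place only: 4-fluorophenoxy in place of benzyl on a saturated chain carbon bound to a saturated ring carbon. Going by the values given here, no measured pair shows this particular change, so the expectation rests on the value of compound 1 alone. The step of a 1.1-fold higher number from compound 1 to compound 4 (0.06 log units; within the scatter) is expected to be small, within the usual scatter, with no clear direction. Compound 4 is accordingly expected to give about 5000 nM in this assay, within a range from 2000 nM to 12000 nM.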

Compound 4, solubility: 17500 nM
The estimate for compound 4 lay 3.5-fold (0.54 log units) below the measured number; the measured number lies above the stated range.
By their numbers in this assay, from the lowest: compound 1; then compounds 3, 4 and 2 (each within the scatter of the next, the first and the last beyond it).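

In this assay, putting 4-fluorophenoxy in place of benzyl on a saturated chain carbon bound to a saturated ring carbon gives a 4.0-fold higher number from compound 1 to compound 4 (0.60 log units; beyond the scatter), a modest step. For the compounds shown here, this is the first step that isolates a single place, and it shows that a change at this position alone, with the rest of compound 1 kept, moves the number beyond the scatter. Nothing available on these compounds bears on why the number rises.

Which part of the incoming group goes with the step stays open: this one change brings in both an oxygen and a fluorine, and a plain phenoxy would separate them. As far as these compounds go, what a morpholine or a carboxylic acid would give in the same place on compound 1 also remains open.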